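The source may report more compounds than this note shows. Statements on the series, on what has been measured and on what is new or still open speak of the compounds shown alone.

Working notes on the series. In a functional assay on KB cells (Homo sapiens) for antiproliferative activity, read by MTT assay (a higher number here means a weaker inhibitor, a lower number a stronger inhibitor), compound 1 `COc1ccc(-c2nc(N3CCNCC3)nc3ccccc23)c(OC)c1` gives 50 ug/mL. Compound 3 `Cn1cc(-c2nc(N3CCNCC3)nc3ccccc23)c2ccccc21` gives 50 ug/mL, level with compound 1, and together they hold the highest of the three numbers. Compound 2 `CN1CCN(c2nc(-n3ccc4ccccc43)c3ccccc3n2)CC1` gives 4.9 ug/mL, well beyond the scatter on the lower side of compound 1.

Compound 4 `COc1ccc(-c2nc(N3CCN(C)CC3)nc3ccccc23)c(OC)c1` is the next to be read in this assay. It departs from compound 1 by methyl in place of hydrogen on an amine nitrogen in a ring, or piperazin-1-yl to 4-methylpiperazin-1-yl.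

For the measured compounds named here, no measured pair isolates this change. Compound 2, at 4.9 ug/mL, also carries 4-methylpiperazin-1-yl, but it differs from compound 1 elsewhere too, so it offers only a weak hint towards a lower number. The expected step, a 2.0-fold lower number from compound 1 to compound 4 (0.30 log units; within the scatter), is therefore modest and may not clear the scatter by much. For compound 4 the estimated value is 25 ug/mL, with an expected range of 7 ug/mL to 60 ug/mL.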

Compound 4, half-maximal inhibitory concentration: 50 ug/mL
The estimate for compound 4 lay 2.0-fold (0.30 log units) below the measured number; low and high end bracket the measured number.
By their numbers in this assay, from the lowest: compound 2; then compounds 1, 3 and 4 (each within the scatter of the next).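

In this assay, for the compounds shown here, the pair gives no change at the digits printed from compound 1 to compound 4 (within the scatter) for methyl in place of hydrogen on an amine nitrogen in a ring, the first reading that isolates this change. On the core of compound 1, piperazin-1-yl and 4-methylpiperazin-1-yl therefore cannot be told apart in this assay, so the amine hydrogen can give way to methyl with no readable shift. Going by these compounds alone, the weak hint drawn from compound 2 finds no support in this pair. No available evidence bears on this result.

Going by these compounds, whether a longer chain such as ethyl, or an acetyl group, on the same nitrogen would leave the number level remains open. So does whether the same methyl change would read alike on the core of compound 3.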